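The source may report more compounds than this note shows. Statements on the series, on what has been measured and on what is new or still open speak of the compounds shown alone.

Working notes on the series. Compound 1 `COc1cc(/C=N/Nc2nc(-c3ccccc3)cs2)c(Br)c(Br)c1OC` is the reference; in a functional assay on Caco-2 cells (Homo sapiens) for inhibition, read by MTT assay, with a stated time of 48 h (on this read-out higher numbers stand for weaker inhibition and lower numbers for stronger inhibition), compound 1 gives 26500 nM. Compound 2 `COc1cc(/C=N/Nc2nc(-c3cccc(Br)c3)cs2)c(Br)c(Br)c1OC` differs by bromo in place of hydrogen on an aromatic carbon. In this assay compound 2 reaches > 100000 nM, which is a limit of the assay and not a number. The step of an at least 3.7-fold higher number from compound 1 to compound 2 (0.57 log units; beyond the scatter) is thus only bounded, its size set by the limit of > 100000 nM in this assay, at which 1 of the 2 values shown sits. Compound 3 `COc1cc(/C=N/Nc2nc(-c3ccc(Br)cc3)cs2)c(Br)c(Br)c1OC` is the next compound, with 4-bromophenyl in place of 3-bromophenyl on an aromatic carbon. For the measured compounds named here, no measured step moves the bromo from one aromatic carbon to another; the single step of an at least 3.7-fold higher number from compound 1 to compound 2 (0.57 log units; beyond the scatter) concerns only its presence, and it went toward weaker inhibition. Compound 3 is expected to sit close to compound 2. The step of a number no higher from compound 2 to compound 3 (the limit leaves the size open) is estimated as none beyond the scatter. In this assay compound 3 is estimated at 100000 nM, in the range 30000 nM to 300000 nM.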

Compound 3, half-maximal inhibitory concentration: > 100000 nM
Compound 3 was reported as a limit; the forecaster's own chance of this, stated with the estimate: 60%; the middle value lies on the limit itself.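

With 4-bromophenyl as with 3-bromophenyl, a bromo on the phenyl group at this position goes with weaker inhibition in this assay, so the loss is not tied to a single placement of the bromo: an at least 3.7-fold higher number from compound 1 to compound 3 (0.57 log units; beyond the scatter). The value of compound 3 is a limit of the assay and not a number. The step between the two bromo placements cannot be read, so neither placement can be ranked over the other, the reading being capped: the limit of > 100000 nM in this assay, at which 2 of the 3 values shown sit.

Open, from the compounds shown here alone, is whether an amine or a carboxylic acid in place of the bromo on the phenyl group would keep, strengthen or weaken the inhibition seen with compound 1. Also open, going by these compounds, is how far compound 2 and compound 3 lie beyond the limit.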